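Working notes: hydroxymethyl in place of formyl on compound 3

The compounds below may be only part of what the source reports. "The series", "measured", "known", "first", "only" and "open" are said of these compounds alone.

Measured in a functional assay on OVCAR-5 cells (Homo sapiens) for inhibition, with a stated time of 48 h, tested at 50 uM; on this read-out higher numbers stand for more inhibition of growth at the one concentration tested and lower numbers for less inhibition of growth:
- compound 1 `CC[C@](C)(CCCC(C)C)CCc1ccc(O)cc1`: 43%
- compound 2 `COc1ccc(/C=C/[C@@](C)(/C=C/c2ccc(O)cc2)CCC=C(C)C)cc1`: 20%
- compound 3 `COc1ccc(/C=C/[C@@](C)(/C=C/c2ccc(O)cc2)CCC=C(C)C)cc1C=O`: 33%

In this assay, compound 3 at 33% lies within the scatter of compound 1 at 43% and clearly above compound 2 at 20%.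

Compound 4 `COc1ccc(/C=C/[C@@](C)(/C=C/c2ccc(O)cc2)CCC=C(C)C)cc1CO` carries hydroxymethyl in place of formyl on an aromatic carbon, ortho to a methoxy group: hydroxymethyl in place of formyl on an aromatic carbon.

Within the data shown here, one measured step bears on this place: formyl in place of hydrogen gave a number 13 percentage points higher from compound 2 to compound 3 (beyond the scatter), a modest change. Among the measured compounds shown here, no measured compound carries hydroxymethyl, so only a small fall is expected, smaller than that step and probably inside the scatter.

The expected step is a number 5 percentage points lower from compound 3 to compound 4 (within the scatter).

The estimate for compound 4 is 28%, with an expected range of 15% to 42%.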

Compound 4, percent growth inhibition at one concentration: 38%
Compound 4: middle estimate off by 10 percentage points, on the low side; measured number inside the range.
By their numbers in this assay, from the lowest: compound 2; then compounds 3, 4 and 1 (each within the scatter of the next).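

In this assay, hydroxymethyl in place of formyl on this aromatic carbon gives a number 5 percentage points higher from compound 3 to compound 4 (within the scatter) and so does not separate the two groups, although only hydroxymethyl adds a hydrogen-bond donor. Hydroxymethyl in place of hydrogen gives a number 18 percentage points higher from compound 2 to compound 4 (beyond the scatter) and shows that the earlier gain over compound 2 is not confined to formyl: both groups here stand clearly above hydrogen. Nothing at hand accounts for either step.

Open, as far as these compounds go, is whether an amine, a carboxylic acid or a longer chain on this carbon would fit the same picture. A single concentration also leaves the shape of the response of compound 3 and compound 4 unresolved.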